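A few compounds are considered here, and "the series" means these few. Any claim that something is new, unique, unknown or untested is made for them only; others in the source may bear on it.

Among the measured compounds shown here, in a functional assay on HepG2 cells (Homo sapiens) for antiproliferative activity, read by MTT assay (on this read-out lower numbers stand for stronger inhibition and higher numbers for weaker inhibition), compound 2 `O=C(Nc1cccc(CNc2ncnc3ccccc23)c1)Nc1ccccc1F` gives 17500 nM, the only plain number reported for this set. Compound 1 `Cc1ccccc1NC(=O)Nc1cccc(CNc2ncnc3ccccc23)c1` gives > 50000 nM, which is a limit of the assay rather than a number. For the measured compounds named here, the single measured step, an at least 2.8-fold lower number from compound 1 to compound 2 (0.45 log units; beyond the scatter), alters the same aryl ring that compound 3 `O=C(Nc1ccc([N+](=O)[O-])cc1)Nc1cccc(CNc2ncnc3ccccc23)c1` changes through (4-nitrophenyl in place of 2-fluorophenyl on an amide-type nitrogen), yet no measured step covers that particular replacement, so the direction remains open and only a modest shift is assumed. Compound 3 is therefore expected to show a 1.2-fold lower number from compound 2 to compound 3 (0.07 log units; within the scatter) and is estimated at 15000 nM, between 4000 nM and 50000 nM.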

Compound 3, half-maximal inhibitory concentration: 24600 nM
Compound 3: the middle estimate sits 1.6-fold (0.21 log units) below what was measured; the range from low to high includes it.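

In this assay, putting 4-nitrophenyl in place of 2-fluorophenyl on the amide-type nitrogen gives a 1.4-fold higher number from compound 2 to compound 3 (0.15 log units; within the scatter) and so separates these two groups by no more than the usual scatter. The change from 2-methylphenyl gives an at least 2.0-fold lower number from compound 1 to compound 3 (0.30 log units; that floor lies within the scatter) and thus shows no clear gain at its floor. Compound 1 is recorded only as a limit of the assay, not as a number: the limit of > 50000 nM in this assay, at which 1 of the 3 values shown sits. The compounds shown leave open whether an amine or a carboxylic acid on this aryl ring would move the number beyond the scatter.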